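The compounds below may be only part of what the source reports. "The series", "measured", "known", "first", "only" and "open" are said of these compounds alone.

In a physicochemical assay for solubility, using the shake flask method, in phosphate buffer, with a stated time of 24 h, at pH 7.4 (a lower number here means a less soluble compound, a higher number a more soluble compound), compound 1 (`CC(Sc1nc2c(cnn2C)c(=O)n1-c1ccccc1)c1ccccn1`) gives 20000 nM and holds the lower of the two actual numbers in the series. Compound 3 (`CC(Sc1nc2nn(C3COC3)cc2c(=O)n1-c1ccccc1)c1ccccn1`) stands higher at 60000 nM and is the nearest neighbour of compound 1 on that scale. For compound 2 (`COc1cccc(C(C)Sc2nc3c(cnn3C)c(=O)n2-c2ccccc2)c1`) the reading is < 2000 nM and this is a limit of this assay rather than a number.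

Compound 4 (`Cn1ncc2c(=O)n(-c3ccccc3)c(SCc3cccc(F)c3)nc21`) has not yet been measured. It carries 3-fluorobenzyl in place of 1-(pyridin-2-yl)ethyl on a sulfur.

Within the data shown here, one measured step bears on this change: an at least 10-fold lower number from compound 1 to compound 2 (1.00 log units; beyond the scatter) with 3-methoxyphenyl in place of pyridin-2-yl, and it lies beyond the scatter. From the compounds shown here alone, that step ends at a limit, so its full size remains open. Like compound 2, compound 4 gives up the pyridin-2-yl for a ring of carbon only, so a fall of similar size is expected in this assay on the strength of an at least 10-fold lower number from compound 1 to compound 2 (1.00 log units; beyond the scatter) alone. The estimated step is an 8.0-fold lower number from compound 1 to compound 4 (0.90 log units; beyond the scatter) in the downward direction, and a reading at the limit is a real possibility. Compound 4 is expected at about 2500 nM with an estimated range from 1000 nM to 8000 nM around that figure.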

Compound 4, solubility: < 700 nM
Compound 4 ended at the assay's limit (the forecaster's own chance of this, stated with the estimate: 50%); at least 3.5-fold (0.55 log units) between middle value and limit.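

In this assay, among these compounds, replacing the whole 1-(pyridin-2-yl)ethyl on the sulfur with 3-fluorobenzyl gives an at least 28-fold lower number from compound 1 to compound 4 (1.45 log units; beyond the scatter), so the fall is no longer tied to the single change to 3-methoxyphenyl. Compound 4 reads < 700 nM, which is a limit of this assay and not a number, so the full size of the step remains open: the limit of < 700 nM in this assay, at which 1 of the 4 values shown sits.

With an at least 10-fold lower number from compound 1 to compound 2 (1.00 log units; beyond the scatter) alongside it, both changes that give up the pyridin-2-yl at this position now end at a lower number, and no compound shown goes against this, though the pattern rests on only these two steps.

Compound 4 differs from compound 1 in both the ring and the chain, so the part played by the ring nitrogen cannot be separated from that of the extra chain carbon, and the two limits leave compound 2 and compound 4 unranked. A pyridin-2-ylmethyl group on the sulfur would separate those two parts, while a benzyl group carrying a carboxylic acid or a dimethylamino group remains an open test of whether a carbon-only ring can read clear of the limit.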